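This account rests on a few compounds, and the source may have more. Where it says the series, first, only, none or still open, it means among the compounds named here.

Measured compounds:
compound 1 `O=C(Nc1cccc(-c2oc3cc(-c4ccc(F)cc4)ccc3c(=O)c2O)c1)c1ccccc1F` — 10100 nM
compound 2 `COc1cccc(C(=O)Nc2cccc(-c3oc4cc(-c5ccc(F)cc5)ccc4c(=O)c3O)c2)c1` — 9950 nM
compound 3 `O=C(Nc1cccc(-c2oc3cc(-c4ccc(F)cc4)ccc3c(=O)c2O)c1)c1cccc(F)c1` — 15500 nM

Three amides sharing one core have been tested in a functional assay on HepG2 cells (Homo sapiens) for antiproliferative activity, read by CCK-8 assay, with a stated time of 72 h; on this read-out lower numbers stand for stronger inhibition and higher numbers for weaker inhibition. Compound 1 gives 10100 nM, compound 2 gives 9950 nM and compound 3 gives 15500 nM. Compound 3 has the highest number of the three, but the steps to it are small: a 1.5-fold higher number from compound 1 to compound 3 (0.19 log units; within the scatter) and a 1.6-fold higher number from compound 2 to compound 3 (0.19 log units; within the scatter), and the step of a 1.0-fold lower number from compound 1 to compound 2 (0.01 log units; within the scatter) is likewise within the scatter, so all three values sit together.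

Compound 4 `N#Cc1ccc(C(=O)Nc2cccc(-c3oc4cc(-c5ccc(F)cc5)ccc4c(=O)c3O)c2)cc1` has not yet been measured. It differs from compound 3 in one place: 4-cyanophenyl in place of 3-fluorophenyl on a carbonyl carbon. Among the measured compounds shown here, no measured step exchanges the aryl group on the carbonyl carbon for a 4-cyanophenyl, so the bearing of the three steps is indirect: they show that changing the substituent on this aryl group, whether fluoro to methoxy or a shift of position, left the numbers in this assay within the scatter of one another. By that pattern compound 4 is expected to land close to compound 3, with an expected step of a 1.3-fold lower number from compound 3 to compound 4 (0.11 log units; within the scatter). The estimate for compound 4 in this assay is therefore 12000 nM, with a range from 5000 nM to 28000 nM.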

Compound 4, half-maximal inhibitory concentration: 7110 nM
Compound 4: the middle estimate sits 1.7-fold (0.23 log units) above what was measured; the range from low to high includes it.
By their numbers in this assay, from the lowest: compounds 4, 2, 1 and 3 (each within the scatter of the next, the first and the last beyond it).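

In this assay, among the compounds shown here, the 4-cyanophenyl on the carbonyl carbon is the first exchange at this position to carry the number beyond the scatter, with a 2.2-fold lower number from compound 3 to compound 4 (0.34 log units; beyond the scatter) as a modest step, whereas the changes among the three earlier aryl groups all stayed within it. The same group does not separate compound 4 from the other two amides, with a 1.4-fold lower number from compound 2 to compound 4 (0.15 log units; within the scatter) and a 1.4-fold lower number from compound 1 to compound 4 (0.15 log units; within the scatter) both within the scatter, so the four compounds form a chain of close values in which only compound 3 and compound 4 stand apart, and this position has so far tolerated every aryl group shown with little change in the number. Nothing measured on these compounds bears on the reason for the step from compound 3 to compound 4.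

The compounds shown leave open whether a 3-cyanophenyl would behave like the 4-cyanophenyl, and what an amine, a carboxylic acid or a longer chain on this aryl group would do to the number. They also leave open what happens when the aryl group on the carbonyl carbon gives way to a saturated ring such as cyclohexyl.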